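This account rests on a few compounds, and the source may have more. Where it says the series, first, only, none or still open, it means among the compounds named here.

Values in a functional assay on HCT-116 cells (Homo sapiens) for inhibition, read by sulforhodamine B assay, with a stated time of 48 h; on this read-out higher numbers stand for lower toxicity in this test and lower numbers for higher toxicity in this test:
- compound 1 `COc1cc(-c2nn(-c3cccc(NC(=O)Nc4cc(C(F)(F)F)cc(C(F)(F)F)c4)c3)cc2-c2ccncc2)ccc1Cl`: 4830 nM
- compound 2 `COc1cc(-c2nn(-c3cccc(NC(=O)c4cccc(C(F)(F)F)c4)c3)cc2-c2ccncc2)ccc1Cl`: > 50000 nM (a limit)
- compound 3 `COc1cc(-c2nn(-c3cccc(NC(=O)Nc4cccc(C(F)(F)F)c4)c3)cc2-c2ccncc2)ccc1Cl`: > 50000 nM (a limit)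

Compound 3 stands at the limit of > 50000 nM in this assay, at which 2 of the 3 values shown sit, so it has a limit and no number. Compound 4 `COc1cc(-c2nn(-c3cccc(NC(=O)Nc4ccc(Cl)c(C(F)(F)F)c4)c3)cc2-c2ccncc2)ccc1Cl` has chloro in place of hydrogen on an aromatic carbon, ortho to a trifluoromethyl group and para to a large group: chloro in place of hydrogen on an aromatic carbon. The nearest measured change is an at least 10-fold higher number from compound 1 to compound 3 (1.01 log units; beyond the scatter), with hydrogen in place of trifluoromethyl on an aromatic carbon. The other measured change, a step that the two limits leave unreadable from compound 2 to compound 3, gives no size to work from. Read in reverse, the first suggests a large fall in this assay on adding a group to compound 3, though a single step is thin support. The expected change is an at least 5.5-fold lower number from compound 3 to compound 4 (0.74 log units; beyond the scatter). Compound 4 is estimated at 9000 nM, with an expected range of 2500 nM to 40000 nM.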

Compound 4, concentration lethal to 50% of the cells: 21500 nM
Beside the measured number, compound 4's estimate is 2.4-fold (0.38 log units) below it, and the stated range covers the measured number.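

In this assay, chloro in place of hydrogen on an aromatic carbon, ortho to a trifluoromethyl group and para to a large group, gives an at least 2.3-fold lower number from compound 3 to compound 4 (0.36 log units; beyond the scatter) and so brings a readable value where the parent gave none. The same chlorinated aryl group on the amino side of the carbonyl gives an at least 2.3-fold lower number from compound 2 to compound 4 (0.36 log units; beyond the scatter) against the 3-(trifluoromethyl)phenyl compound. Both steps are only bounds, since compound 2 and compound 3 carry a limit and no number: the limit of > 50000 nM in this assay, at which 2 of the 4 values shown sit.

On these data alone, the true size of both steps stays open. So does how fluoro, methoxy or an amine at this position would read in this assay.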